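A few compounds are considered here, and "the series" means these few. Any claim that something is new, unique, unknown or untested is made for them only; others in the source may bear on it.

Compound 1 `Cc1nc(Nc2cccc(Cl)c2)sc1C(=O)/C=C/c1ccccc1`: in a functional assay on Bel-7402 cells (Homo sapiens) for cytotoxicity, read by MTT assay (on this read-out lower numbers stand for stronger inhibition and higher numbers for weaker inhibition), compound 1 gives only a limit, > 25000 nM.
Compound 2 `Cc1nc(Nc2ccccc2)sc1C(=O)/C=C/c1ccc(Cl)cc1`: in this assay compound 2 gives only a limit, > 25000 nM.
Compound 3 `Cc1ccc(Nc2nc(C)c(C(=O)/C=C/c3ccc(Cl)cc3)s2)cc1`: in this assay compound 3 gives only a limit, > 25000 nM.

Compound 3 therefore stands at a limit of this assay and not at a number. Among the measured compounds shown here, the one measured step, a step that the two limits leave unreadable from compound 2 to compound 3, is unreadable because of the limit of > 25000 nM in this assay, at which 3 of the 3 values shown sit, so it gives no guide to the size of any change here. Compound 4 `Cc1nc(Nc2cccc(Cl)c2)sc1C(=O)/C=C/c1ccc(Cl)cc1` differs from compound 3 by 3-chlorophenyl in place of 4-methylphenyl on a nitrogen on an aromatic ring. For the measured compounds named here, no measured step bears directly on this change; compound 1, which carries the same 3-chlorophenyl on the nitrogen, sits at the same limit as the other two, and nothing among the measured values points to a readable gain. Compound 4 is therefore expected to remain at the limit of this assay as well, with an estimate of 35000 nM and a range from 10000 nM to 120000 nM. The step expected from compound 3 to compound 4, a step that the limit leaves unreadable from compound 3 to compound 4, is not expected to stand out from the scatter.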

Compound 4, half-maximal inhibitory concentration: > 25000 nM
Compound 4 gave a limit, no number; the forecaster's own chance of this, stated with the estimate: 80%; the middle value lies beyond the limit too.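

The steps from compound 1, compound 2 and compound 3 to compound 4 cannot be read, because all four compounds stand at the same limit: the limit of > 25000 nM in this assay, at which 4 of the 4 values shown sit. The compounds shown leave open which change, if any, would give a measurable value in this assay on the shared core.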